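A few compounds are considered here, and "the series" means these few. Any claim that something is new, unique, unknown or untested is made for them only; others in the source may bear on it.

In an ADME assay on Huh-7 cells (Homo sapiens) for cytotoxicity (on this read-out lower numbers stand for higher toxicity in this test and higher numbers for lower toxicity in this test), compound 1 `O=C(NC(=S)N1CCc2cc(OCc3ccccc3)ccc21)c1ccccc1` gives 45200 nM, and compound 2 `O=C(NC(=S)N1CCc2ccc(OCc3ccccc3)cc21)c1ccccc1` gives 43800 nM; these two values lie within the scatter of each other. Compound 3 `N#Cc1ccc(C(=O)NC(=S)N2CCc3c(OCCCCCOc4ccc(Cl)cc4)cccc32)cc1` is reported in this assay only as a limit, > 50000 nM, and not as a number. That limit is where compound 3 stands, one of the three values shown sitting there (the limit of > 50000 nM in this assay, at which 1 of the 3 values shown sits). The step from compound 3 to compound 4 `O=C(NC(=S)N1CCc2c(OCCCCCOc3ccc(Cl)cc3)cccc21)C1CCCCC1` is cyclohexyl in place of 4-cyanophenyl on a carbonyl carbon. For the measured compounds named here, no pair of measured compounds differs in one place only, so no measured step guides a reading of this change. Compound 4 is expected to remain near the top of the range that this assay covers, with a step of a number no higher from compound 3 to compound 4 (the limit leaves the size open) that is expected to be none beyond the scatter. On that basis compound 4 is estimated at 50000 nM, between 25000 nM and 100000 nM, with a fair chance that only a limit is reported again.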

Compound 4, half-maximal cytotoxic concentration: > 50000 nM
Compound 4: only a limit was reported (the forecaster's own chance of this, stated with the estimate: 55%); the middle value lies on the limit itself.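

No new step can be read: compound 3 and compound 4 are both reported only as limits in this assay, so cyclohexyl in place of 4-cyanophenyl on a carbonyl carbon has no readable effect. The compounds shown leave open how far either compound lies beyond that limit.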